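The source may report more compounds than this note shows. Statements on the series, on what has been measured and on what is new or still open speak of the compounds shown alone.

Measured in a functional assay on Malme-3M cells (Homo sapiens) for antiproliferative activity, read by sulforhodamine B assay, with a stated time of 48 h; on this read-out higher numbers stand for weaker inhibition and lower numbers for stronger inhibition:
- compound 1, `Nc1cccc2c(-c3cccc(NC(=O)c4ccc(Cl)c(C(F)(F)F)c4)c3)ccnc12`, gives 4900 nM
- compound 2, `Nc1cccc2c(-c3cccc(NC(=O)c4nccs4)c3)ccnc12`, gives 12500 nM
- compound 3, `COc1ccc(C(=O)Nc2cccc(-c3ccnc4c(NC(C)=O)cccc34)c2)cc1OC`, gives 2000 nM

On these numbers compound 3 stands lowest of the three in this assay. Its nearest neighbour is compound 1, whose higher number lies beyond the scatter; the furthest is compound 2, also beyond the scatter. Among the measured compounds shown here, no pair among the measured compounds differs in only one place, so no single step can be read from them as yet.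

Compound 4, `CC(=O)Nc1cccc2c(-c3cccc(NC(=O)c4ccc(Cl)c(C(F)(F)F)c4)c3)ccnc12`, has not been measured in this assay. It differs from compound 3 in one place: 4-chloro-3-(trifluoromethyl)phenyl in place of 3,4-dimethoxyphenyl on a carbonyl carbon. Compound 1 carries the same entering group as compound 4 but differs from compound 4 in another place as well, so the gap between the value of compound 1 and that of compound 3 cannot be attributed to the amide group on its own.

For the measured compounds named here, with no direct step available, the step from compound 3 to compound 4 is expected to be modest, a 1.5-fold higher number from compound 3 to compound 4 (0.18 log units; within the scatter), toward a somewhat higher number, and may well fall within the scatter. Compound 4 is therefore expected to give about 3000 nM in this assay, with a range from 900 nM to 10000 nM.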

Compound 4, half-maximal inhibitory concentration: 2700 nM
Beside the measured number, compound 4's estimate is 1.1-fold (0.05 log units) above it, within the range that was stated.
By their numbers in this assay, from the lowest: compounds 3, 4 and 1 (each within the scatter of the next, the first and the last beyond it); then compound 2.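

Among the compounds shown here, replacing 3,4-dimethoxyphenyl with 4-chloro-3-(trifluoromethyl)phenyl on a carbonyl carbon gives a 1.4-fold higher number from compound 3 to compound 4 (0.13 log units; within the scatter) in this assay and is the first single change that can be read at this position. With the acetyl group held on the nitrogen, these two aryl groups are therefore not told apart on this read-out, even though one carries two methoxy groups and the other carries chlorine and trifluoromethyl. At the other changed place, with 4-chloro-3-(trifluoromethyl)phenyl held, acetyl in place of hydrogen on a nitrogen on an aromatic ring gives a 1.8-fold lower number from compound 1 to compound 4 (0.26 log units; within the scatter) and so also leaves the two compounds unseparated.

Still open, as far as these compounds go, is whether a non-aromatic group on the carbonyl carbon, such as cyclohexyl or a longer alkyl chain, or an aryl group bearing a carboxylic acid or an amine, would give a step beyond the scatter. From the compounds shown here alone, it is also open whether a longer acyl chain in place of acetyl on the nitrogen would do so, or whether the acetyl step would stay the same with 3,4-dimethoxyphenyl on the carbonyl carbon.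

No accompanying data bear on the reason for either step.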